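Methoxy to Hydroxy: Expected Tolerance of Compound 3

This account rests on a few compounds, and the source may have more. Where it says the series, first, only, none or still open, it means among the compounds named here.

Among the two compounds with numbers, compound 2 `COc1cccc(N2C(=O)/C(=C/c3cc(C)n(-c4cccc(-c5nnn[nH]5)c4)c3C)SC2=S)c1` stands lowest in an ADME assay on MT2 cells (Homo sapiens) for cytotoxicity, read by XTT assay, with a stated time of 4 days (a higher number here means that more compound is tolerated, a lower number that less compound is tolerated), where compound 2 gives 40600 nM. Compound 1 `Cc1ccc(C)n1-c1cccc(-c2nnn[nH]2)c1` gives 250000 nM in this assay, a higher number that lies beyond the scatter. Compound 3 `Cc1cc(/C=C2\SC(=S)N(c3cccc(O)c3)C2=O)c(C)n1-c1cccc(-c2nnn[nH]2)c1` differs from compound 2 in one place: hydrogen in place of methyl on an oxygen on an aromatic ring. Among the measured compounds shown here, no pair of measured compounds shows this change, so no measured step guides it. Compound 3 is expected to give a step of a 1.1-fold higher number from compound 2 to compound 3 (0.04 log units; within the scatter) in this assay, which would stay within the scatter. Compound 3 is estimated at 45000 nM, between 15000 nM and 130000 nM.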

Compound 3, half-maximal cytotoxic concentration: 35600 nM
For compound 3 the middle estimate is 1.3-fold (0.10 log units) above the measured one; low and high end bracket the measured number.
By their numbers in this assay, from the lowest: compounds 3 and 2 (each within the scatter of the next); then compound 1.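

In this assay, going from 3-methoxyphenyl to 3-hydroxyphenyl gives a 1.1-fold lower number from compound 2 to compound 3 (0.06 log units; within the scatter), so at this place, on an oxygen on an aromatic ring, losing the methyl does not separate the two compounds. Among the compounds shown here, this is the first reading of the change, and it holds for this one pair only. Nothing measured here bears on why the two compounds read alike. The compounds shown leave open whether an amine or a carboxylic acid in place of the hydroxy, or a longer chain on that oxygen, would read differently.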